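Three sulfonamides at the assay limit; a halogenated fourth

The source may hold more compounds than are shown below. What is called first, only, known or untested is meant among the compounds shown, and "the series" means these compounds.

Compound 1, `COc1ccc(S(=O)(=O)NC2=NCCN2C(=S)SN2CCn3c2nsc3=S)cc1`: in a functional assay on KYSE-510 cells (Homo sapiens) for antiproliferative activity, read by crystal violet staining, with a stated time of 96 h (on this read-out lower numbers stand for stronger inhibition of growth and higher numbers for weaker inhibition of growth), compound 1 gives >= 20000 nM, which is a limit of the assay and not a number.
Compound 2, `O=S(=O)(NC1=NCCN1C(=S)SN1CCn2c1nsc2=S)c1ccc(OC(F)(F)F)cc1`: in this assay compound 2 gives >= 20000 nM, again a limit.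
Compound 3, `O=[N+]([O-])c1ccc(S(=O)(=O)NC2=NCCN2C(=S)SN2CCn3c2nsc3=S)cc1`: in this assay compound 3 gives >= 20000 nM, also a limit.

Compound 3 therefore stands nowhere in particular among the three: all sit at the limit of >= 20000 nM in this assay, at which 3 of the 3 values shown sit, and the steps a step that the two limits leave unreadable from compound 1 to compound 3 and a step that the two limits leave unreadable from compound 2 to compound 3, like a step that the two limits leave unreadable from compound 1 to compound 2, cannot be read in size or direction. Nothing shows whether swapping one ring substituent for another moves growth inhibition at all.

The unmeasured compound 4, `O=S(=O)(NC1=NCCN1C(=S)SN1CCn2c1nsc2=S)c1ccc(F)c(Cl)c1`, differs from compound 3 by 3-chloro-4-fluorophenyl in place of 4-nitrophenyl on a sulfonyl sulfur. No measured step bears on this change, so no size of step in this assay can be expected from the data; the three limits suggest only that the shared core with a substituted phenyl sulfonamide has not yet shown measurable activity.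

Compound 4 is estimated to give 25000 nM, between 8000 nM and 80000 nM, most likely again as a limit. The expected step is a step that the limit leaves unreadable from compound 3 to compound 4.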

Compound 4, concentration for 50% growth inhibition: >= 20000 nM
Compound 4: a limit, no number; the forecaster's own chance of this, stated with the estimate: 70%; the middle value is on the limit's open side.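

Compound 4 also gives a limit and not a number, so the steps to it from compound 1 and from compound 3 cannot be read in size or direction: the limit of >= 20000 nM in this assay, at which 4 of the 4 values shown sit.

The compounds shown leave open whether changing the group on the sulfonyl sulfur affects growth inhibition at all.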